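The source may hold more compounds than are shown below. What is called first, only, known or untested is meant among the compounds shown, and "the series" means these compounds.

Measured compounds:
compound 1, `Cn1c(=O)c(S(=O)(=O)c2ccc(Cl)cc2Cl)cc2cnc(Nc3ccc4[nH]ccc4c3)nc21`, 1000 nM
compound 2, `Cn1c(=O)c(S(=O)(=O)c2ccc(F)cc2F)cc2cnc(Nc3ccc4cc[nH]c4c3)nc21`, 5000 nM
compound 3, `Cn1ccc2cc(Nc3ncc4cc(S(=O)(=O)c5ccc(Cl)cc5Cl)c(=O)n(C)c4n3)ccc21`, 750 nM

In a functional assay on DU-145 cells (Homo sapiens) for inhibition, read by trypan blue exclusion, with a stated time of 72 h (a lower number here means a stronger inhibitor, a higher number a weaker inhibitor), compound 1 sits second highest of the three numbers. Its nearest neighbour is compound 3, reached by a 1.3-fold lower number from compound 1 to compound 3 (0.12 log units; within the scatter), so the two cannot be told apart. For the measured compounds named here, compound 2 gives a higher number than compound 1, and that gap lies beyond the scatter; the two differ in more than one place, so no single step links them.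

Compound 4, `Cn1c(=O)c(S(=O)(=O)c2ccc([N+](=O)[O-])cc2F)cc2cnc(Nc3ccc4[nH]ccc4c3)nc21`, is not yet measured. It differs from compound 1 by 2-fluoro-4-nitrophenyl in place of 2,4-dichlorophenyl on a sulfonyl sulfur. Going by the values given here, no measured step changes the group on the sulfonyl sulfur on its own, so nothing measured bears directly on this change; the one recorded step alters a distant aromatic nitrogen and stays within the scatter. The expectation is therefore cautious: the number for compound 4 is estimated at 1500 nM, with a range from 500 nM to 6000 nM. The expected step is a 1.5-fold higher number from compound 1 to compound 4 (0.18 log units; within the scatter), a change not clearly beyond the scatter in either direction.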

Compound 4, half-maximal inhibitory concentration: 400 nM
Compound 4: the middle estimate sits 3.8-fold (0.57 log units) above what was measured; the whole stated range lies above it.
By their numbers in this assay, from the lowest: compounds 4, 3 and 1 (each within the scatter of the next, the first and the last beyond it); then compound 2.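

In this assay, the group on the sulfonyl sulfur proves able to move the number: 2-fluoro-4-nitrophenyl in place of 2,4-dichlorophenyl gives a 2.5-fold lower number from compound 1 to compound 4 (0.40 log units; beyond the scatter), a modest step but a real one. For the compounds shown here, the only earlier single-place change, methyl in place of hydrogen on an aromatic nitrogen, gave a 1.3-fold lower number from compound 1 to compound 3 (0.12 log units; within the scatter), so this is the first change in one place whose effect can be told apart from ordinary repeat variation. Nothing available explains why the number falls with this exchange.

Both substituents on the phenyl ring differ between the two groups, so the compounds shown leave open whether the fluorine, the nitro group or the pair accounts for the step. They also leave open how an amine or a carboxylic acid on that ring would read in this assay.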